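Swapping the aryl group on a naphthyloxy-acetohydrazone scaffold

The source may report more compounds than this note shows. Statements on the series, on what has been measured and on what is new or still open speak of the compounds shown alone.

The measured compounds and their values:
compound 1 `C/C(=N\NC(=O)COc1cccc2ccccc12)c1ccc([N+](=O)[O-])cc1` — 100 ug/mL
compound 2 `O=C(COc1cccc2ccccc12)N/N=C/c1cccc(Br)c1` — 100 ug/mL
compound 3 `O=C(COc1cccc2ccccc12)N/N=C/c1ccc(F)cc1` — 100 ug/mL

Three compounds share one core and differ only in the aryl group attached to the carbon with a double bond to nitrogen. In an ADME assay on HEL cells (Homo sapiens) for cytotoxicity (on this read-out higher numbers stand for lower toxicity in this test and lower numbers for higher toxicity in this test), compound 1 gives 100 ug/mL. In this assay compound 2 gives 100 ug/mL, and compound 3 gives 100 ug/mL. For the measured compounds named here, all three therefore sit at the same level, and the one step actually examined, no change at the digits printed from compound 2 to compound 3 (within the scatter), shows that exchanging one halogenated phenyl group for another left the read-out where it was.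

The next compound, compound 4 `C/C(=N\NC(=O)COc1cccc2ccccc12)c1ccccc1Br`, has not yet been tested. Relative to compound 1 it carries a different aryl group:
2-bromophenyl in place of 4-nitrophenyl on a carbon with a double bond to nitrogen

Going by the values given here, no measured step bears directly on this exchange, since compound 1 has not been compared with anything. What is available is the indifference of the read-out to the aryl group seen across compounds 1, 2 and 3, and the unchanged result in no change at the digits printed from compound 2 to compound 3 (within the scatter). On that basis no step beyond the scatter is expected from compound 1 to compound 4, that is no change at the digits printed from compound 1 to compound 4 (within the scatter). Compound 4 is therefore estimated to give 100 ug/mL, in a range from 50 ug/mL to 200 ug/mL.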

Compound 4, minimum cytotoxic concentration: 20 ug/mL
Estimate against measurement, compound 4: 5.0-fold (0.70 log units) above; the measured number lies below the stated range.
By their numbers in this assay, from the lowest: compound 4; then compounds 1, 2 and 3 (each within the scatter of the next).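

Placing 2-bromophenyl in place of 4-nitrophenyl on this carbon gives a 5.0-fold lower number from compound 1 to compound 4 (0.70 log units; beyond the scatter) in this assay and so points to higher toxicity in this test, a modest step but one beyond the scatter. The level shared by compounds 1, 2 and 3 therefore does not mean that the aryl group at this position has no bearing on the read-out, since this single exchange of aryl groups on the shared core is enough to move it. Nothing measured here gives a reason for the step, which remains an observation without an explanation.

For the compounds shown here, with only this one pair, the step cannot be assigned to the arrival of the bromine, to its place on the ring or to the departure of the nitro group, and compound 4 differs from compound 2 in more than one place, so that pair cannot settle the matter. Also open, going by these compounds, is where the read-out would fall with an unsubstituted phenyl group, or with a phenyl group carrying a methoxy group, an amine or a carboxylic acid, on this same carbon.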